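This account rests on a few compounds, and the source may have more. Where it says the series, first, only, none or still open, it means among the compounds named here.

Compounds measured so far in a functional assay for agonist activity at G protein-coupled receptor 88 (Homo sapiens), read by HTRF and cAMP accumulation; on this read-out lower numbers stand for an effect already at smaller amounts and higher numbers for an effect only at larger amounts of compound:

Compound 1 `CC[C@H](C)[C@H](N)CN(C(=O)[C@@H]1C[C@H]1c1cc(F)cc(F)c1)c1ccc(-c2ccccc2)cc1` gives 960 nM.
Compound 2 `CC(C)C[C@H](N)CN(C(=O)[C@@H]1C[C@H]1c1ccccc1)c1ccc(-c2ccncc2)cc1` gives 13000 nM.
Compound 3 `CC(C)C[C@H](N)CN(C(=O)[C@@H]1C[C@H]1c1ccccc1)c1ccc(-c2ccsc2)cc1` gives 1200 nM.

Among these three numbers compound 3 stands second highest; compound 1 lies within the scatter of it, whereas compound 2 sits well apart, the only step beyond the scatter in the set being an 11-fold lower number from compound 2 to compound 3 (1.03 log units; beyond the scatter).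

Compound 4 `CC(C)C[C@H](N)CN(C(=O)[C@@H]1C[C@H]1c1ccccc1)c1ccc(C2=CCCC2)cc1` has not yet been measured. It differs from compound 3 in one place: cyclopent-1-en-1-yl in place of thiophen-3-yl on an aromatic carbon.

Among the compounds with values here, the one measured step that bears on this position is an 11-fold lower number from compound 2 to compound 3 (1.03 log units; beyond the scatter), which shows that exchanging the group at this site can move this assay strongly. That step, however, replaced a six-membered aromatic ring by a five-membered one; the change to compound 4 keeps a five-membered ring and only drops the acceptor and the aromatic character. Within the data shown here, no measured pair speaks directly to such a swap, so the expectation is a step of modest size, within or near the scatter, and its direction is uncertain. Compound 4 is therefore expected to come out near compound 3, at 1600 nM with a range of 500 nM to 5000 nM, which corresponds to an estimated step of a 1.3-fold higher number from compound 3 to compound 4 (0.12 log units; within the scatter).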

Compound 4, half-maximal effective concentration: 1200 nM
Compound 4: the middle estimate sits 1.3-fold (0.12 log units) above what was measured; measured number inside the range.
By their numbers in this assay, from the lowest: compounds 1, 3 and 4 (each within the scatter of the next); then compound 2.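

In this assay the exchange gives no change at the digits printed from compound 3 to compound 4 (within the scatter), so at this place, on an aromatic carbon para to a large group, a five-membered non-aromatic ring of carbon only reads the same as a five-membered aromatic ring with a sulfur atom. The high number of compound 2 is now set against two different five-membered rings, with an 11-fold lower number from compound 2 to compound 4 (1.03 log units; beyond the scatter) matching an 11-fold lower number from compound 2 to compound 3 (1.03 log units; beyond the scatter), and among these three groups only pyridin-4-yl stands apart. No measurement at hand gives a reason for either result.

As far as these compounds go, whether the gap follows the ring nitrogen of pyridin-4-yl or the six-membered ring size stays open. So does whether a saturated cyclopentyl, a piperidine or a carboxylic acid at this carbon would stay with compound 3 and compound 4 or move toward compound 2.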